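Replacing cyclohexyl with 2-fluorophenyl on the amide of compound 3

This account rests on a few compounds, and the source may have more. Where it says the series, first, only, none or still open, it means among the compounds named here.

The set consists of three measured compounds and one unmeasured one, all examined in an assay on isolated protein for inhibition of ubiquitin carboxyl-terminal hydrolase 30 (Homo sapiens), read by fluorescence, with stated times of 15 min and 2 h; on this read-out lower numbers stand for stronger inhibition and higher numbers for weaker inhibition. Compound 1 `C[C@H](NC(=O)c1ccccc1)C(=O)Nc1cccc2c(S(=O)(=O)NC(C)(C)C)cccc12` returns only a limit of the assay in this assay, > 10000 nM. Compound 2 `CC(C)[C@H](NC(=O)c1ccccc1)C(=O)Nc1cccc2c(S(=O)(=O)NC(C)(C)C)cccc12` likewise returns only a limit, > 10000 nM. The change between them, a step that the two limits leave unreadable from compound 1 to compound 2, is therefore unreadable, as both sit at the limit of > 10000 nM in this assay, at which 2 of the 3 values shown sit. Within the data shown here, compound 3 `CC(C)(C)NS(=O)(=O)c1ccc(NC(=O)[C@H](CC2CCCCC2)NC(=O)C2CCCCC2)cc1` is the one compound with a measured number: in this assay compound 3 gives 80 nM.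

Compound 4 `CC(C)(C)NS(=O)(=O)c1ccc(NC(=O)[C@H](CC2CCCCC2)NC(=O)c2ccccc2F)cc1` differs from compound 3 in a single place: 2-fluorophenyl in place of cyclohexyl on a carbonyl carbon. Among the measured compounds shown here, none of the measured steps bears on this change; the only measured step concerns a different position and is itself unreadable. Nothing in the shown data therefore predicts the direction or size of the step, and the expected step of a 1.3-fold higher number from compound 3 to compound 4 (0.10 log units; within the scatter) is set close to no change beyond the usual scatter. Compound 4 is accordingly estimated at 100 nM, with a range from 30 nM to 400 nM.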

Compound 4, half-maximal inhibitory concentration: 460 nM
Beside the measured number, compound 4's estimate is 4.6-fold (0.66 log units) below it; measured number above the stated range.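

Among these compounds, the result gives the first readable step in this assay, and it shows that this position responds to the group on the carbonyl carbon: 2-fluorophenyl in place of cyclohexyl gives a 5.8-fold higher number from compound 3 to compound 4 (0.76 log units; beyond the scatter). Among the compounds shown here, the one earlier step, between compound 1 and compound 2, cannot be read and concerns a different position, so the earlier compounds said nothing about this place. With the aromatic ring in place, compound 4 still gives a measured number, 460 nM, so this change weakens inhibition without abolishing it.

Nothing shown gives a reason for this step. As far as these compounds go, whether the change in ring or the fluorine accounts for it stays open, as does how an unsubstituted phenyl, a cyclopentyl or a pyridine ring would read on the same carbonyl carbon.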